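Drawing one stereocentre on compound 2

This account rests on a few compounds, and the source may have more. Where it says the series, first, only, none or still open, it means among the compounds named here.

Within the data shown here, in a functional assay on G-361 cells (Homo sapiens) for antiproliferative activity, read by MTT assay, with a stated time of 72 h (on this read-out higher numbers stand for weaker inhibition and lower numbers for stronger inhibition), compound 1 `NC1CCc2nc(-c3ccncc3)nc(Nc3ccc(F)cc3)c2C1` gives 3000 nM and compound 2 `NC1CCc2nc(-c3ccncc3)nc(Nc3cccc(F)c3)c2C1` gives 1400 nM, the lower number so far. Compound 3 `N[C@H]1CCc2nc(-c3ccncc3)nc(Nc3cccc(F)c3)c2C1` differs only in how it is drawn: the two compounds have the same atoms and bonds; at least one stereo element is drawn with a configuration in one of them and without one in the other: 1 of 1 stereo elements differ; a stereocentre at a saturated ring carbon is drawn without a configuration in compound 2 and S in compound 3. A stereocentre at a saturated ring carbon, without a configuration in compound 2, is S in compound 3. Among the measured compounds shown here, the one measured step, a 2.1-fold lower number from compound 1 to compound 2 (0.33 log units; beyond the scatter), is a modest one that puts 3-fluorophenyl in place of 4-fluorophenyl. It involves no configuration and indicates no direction here. The expected change is small, a 1.1-fold lower number from compound 2 to compound 3 (0.03 log units; within the scatter). Compound 3 is estimated at 1300 nM, with an expected range from 500 nM to 3500 nM.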

Compound 3, half-maximal inhibitory concentration: 1600 nM
Estimate against measurement, compound 3: 1.2-fold (0.09 log units) below, within the range that was stated.
By their numbers in this assay, from the lowest: compounds 2, 3 and 1 (each within the scatter of the next, the first and the last beyond it).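

In this assay, setting the stereocentre at a saturated ring carbon to S comes with a 1.1-fold higher number from compound 2 to compound 3 (0.06 log units; within the scatter), so fixing this configuration in the drawing brings no change that can be told from the usual scatter. The comparison can say only so much about the S form because just one side of it has a stated configuration: the fact that one of compounds 2 and 3 is drawn with a defined configuration and the other without, at the place where they differ.

The compounds shown leave open how the R form would compare with compound 3. They also leave open what would happen if a hydroxyl group or an amide replaced the amine on that carbon.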